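A few compounds are considered here, and "the series" means these few. Any claim that something is new, unique, unknown or untested is made for them only; others in the source may bear on it.

Going by the values given here, compound 3 `O=S(=O)(NCCCNCc1ccc(Br)cc1)c1cc(C(F)(F)F)cc(C(F)(F)F)c1` gives 1500 nM in a functional assay on BXPC-3 cells (Homo sapiens) for inhibition, read by MTT assay, with a stated time of 72 h (a lower number here means a stronger inhibitor of growth, a higher number a weaker inhibitor of growth), and sits at the low end of the three numbers known so far. Compound 1 `O=S(=O)(NCCCCNCc1ccc(Br)cc1)c1cc(C(F)(F)F)cc(C(F)(F)F)c1` gives 1700 nM, and the step of a 1.1-fold lower number from compound 1 to compound 3 (0.05 log units; within the scatter) lies within the scatter, so the two cannot be told apart. Compound 2 `O=S(=O)(NCCCNCc1cccc(Cl)c1)c1cc(C(F)(F)F)cc(C(F)(F)F)c1` gives 3800 nM, and the step of a 2.5-fold lower number from compound 2 to compound 3 (0.40 log units; beyond the scatter) is the one clear difference among the measured compounds.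

Compound 4 `COc1ccc(CNCCCNS(=O)(=O)c2cc(C(F)(F)F)cc(C(F)(F)F)c2)cc1` is reached from compound 3 by a single change on the six-membered aromatic ring of carbon only, para to a large group: methoxy in place of bromo on an aromatic carbon. Among the compounds with values here, only one measured step alters this ring at all, the move from 3-chlorophenyl to 4-bromophenyl, a 2.5-fold lower number from compound 2 to compound 3 (0.40 log units; beyond the scatter), and it was modest. Within the data shown here, no measured pair shows bromo being replaced by methoxy, so the direction of the new step is not fixed by the data. The expectation is therefore a step of modest size at most, with a small lean toward a higher number, a 1.7-fold higher number from compound 3 to compound 4 (0.22 log units; within the scatter). Compound 4 is estimated at 2500 nM, within a range from 1000 nM to 6500 nM.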

Compound 4, concentration for 50% growth inhibition: 1300 nM
Beside the measured number, compound 4's estimate is 1.9-fold (0.28 log units) above it; measured number inside the range.
By their numbers in this assay, from the lowest: compounds 4, 3 and 1 (each within the scatter of the next); then compound 2.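

In this assay, methoxy in place of bromo on this aromatic carbon gives a 1.2-fold lower number from compound 3 to compound 4 (0.06 log units; within the scatter), so the two groups cannot be told apart here, even though the entering methoxy is counted as a hydrogen-bond acceptor and the leaving bromo is not. The comparison with the compound carrying ((4-bromobenzyl)amino)methyl also stays inside the scatter, at a 1.3-fold lower number from compound 1 to compound 4 (0.12 log units; within the scatter), while the compound with the 3-chlorophenyl group remains apart, at a 2.9-fold lower number from compound 2 to compound 4 (0.47 log units; beyond the scatter), so that compound's distance now shows against both the 4-bromophenyl and the 4-methoxyphenyl compounds. Nothing measured and shown gives a reason for any of these results.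

Going by these compounds, it remains open whether a group of another kind on this ring carbon, such as an amine or a carboxylic acid, would move the number beyond the scatter. Also open, on these data alone, is whether the distance of compound 2 comes from the chlorine itself or from where it sits on the ring, a question that a 4-chlorophenyl compound could settle.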